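This account rests on a few compounds, and the source may have more. Where it says the series, first, only, none or still open, it means among the compounds named here.

Measured compounds:
- compound 1, `COc1ccc(-c2ccc(-c3ccc(C(=N)N)cc3)s2)cc1`: 192 nM in a functional assay on MDA-MB-468 cells (Homo sapiens) for inhibition, read by sulforhodamine B assay, with a stated time of 48 h; a higher number here means a weaker inhibitor of growth, a lower number a stronger inhibitor of growth
- compound 2, `N=C(N)c1ccc(-c2ccc(-c3cc(Cl)cc(Cl)c3)s2)cc1`: 1030 nM

Both compounds share the same core, which is shown in the structure of compound 1, and differ only in the outer six-membered ring and its substituents. Going by the values given here, of the two numbers measured so far, compound 1 has the lower one, and the gap between compound 1 and compound 2 lies beyond the usual scatter of this assay, so compound 1 is the stronger growth inhibitor of the pair.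

Compound 3, `N=C(N)c1ccc(-c2ccc(-c3ccc(F)cc3)s2)cc1`, has not yet been measured. It differs from compound 1 in one place: fluoro in place of methoxy on an aromatic carbon. Among the compounds with values here, no pair of measured compounds shows exactly this change, so there is no measured step to lean on; the only firm point is the value of compound 1 at 192 nM. The change is small and keeps the outer ring intact, so the step from compound 1 to compound 3 is expected to be modest, a 1.8-fold higher number from compound 1 to compound 3 (0.26 log units; within the scatter), leaning toward a slightly higher number but possibly within the scatter. Compound 3 is therefore expected to give about 350 nM in this assay, within a range from 120 nM to 1000 nM.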

Compound 3, concentration for 50% growth inhibition: 1260 nM
Compound 3: the middle estimate sits 3.6-fold (0.56 log units) below what was measured, and the stated range ends below it.
By their numbers in this assay, from the lowest: compound 1; then compounds 2 and 3 (each within the scatter of the next).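

In this assay, placing fluoro where methoxy stood, on an aromatic carbon para to a large group, gives a 6.6-fold higher number from compound 1 to compound 3 (0.82 log units; beyond the scatter). Going by these compounds alone, this is the first change at a single place, and it shows that this position is not neutral: with the shared core and the rest of the molecule unchanged, replacing this one small group is enough to move the number beyond the scatter, and methoxy here goes with the stronger growth inhibitor. This rests on one pair of compounds, and nothing measured alongside these growth numbers bears on why methoxy and fluoro differ at this position.

The compounds shown leave open whether the higher number follows from losing methoxy or from bringing in fluoro, since a single swap does both at once; a plain hydrogen, a hydroxyl, an amine or a longer chain such as ethoxy at the same carbon would help to separate these two readings. They also leave open whether this swap would give a step of similar size on a different core.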